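Swapping Methylamino for Methyl on a Weak Nucleoside

This account rests on a few compounds, and the source may have more. Where it says the series, first, only, none or still open, it means among the compounds named here.

In a functional assay on A549 cells (Homo sapiens), read by MTT assay, with a stated time of 72 h (on this read-out lower numbers stand for stronger inhibition and higher numbers for weaker inhibition), compound 1 `C#Cc1cn([C@@H]2O[C@H](CO)[C@@H](O)[C@H]2O)c2ncnc(C)c12` gives 19200 nM, a weak result. Compound 2 `CNc1ncnc2c1c(-c1ccsc1)cn2[C@@H]1O[C@H](CO)[C@@H](O)[C@H]1O` reaches only the limit of this assay, > 20000 nM, so no exact number is known for it (the limit of > 20000 nM in this assay, at which 1 of the 2 values shown sits). Compound 3 `Cc1ncnc2c1c(-c1ccsc1)cn2[C@@H]1O[C@H](CO)[C@@H](O)[C@H]1O` is the untested partner: methyl in place of methylamino on an aromatic carbon. Both measured compounds sit at the weak end of this assay, and nothing among them points to a gain from this change. The step of a number no higher from compound 2 to compound 3 (the limit leaves the size open) is therefore expected to stay within the usual scatter, in no clear direction. Compound 3 is estimated at 20000 nM, with a range from 6000 nM to 60000 nM.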

Compound 3, half-maximal inhibitory concentration: > 20000 nM
Compound 3: only a limit was reported; the forecaster's own chance of this, stated with the estimate: 55%; the middle value sits exactly at the limit.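

The step for methyl in place of methylamino on the aromatic carbon next to the ring nitrogen cannot be read, because compound 2 and compound 3 both end at a limit and not at a number: the limit of > 20000 nM in this assay, at which 2 of the 3 values shown sit.

Thiophen-3-yl in place of ethynyl on an aromatic carbon gives an at least 1.0-fold higher number from compound 1 to compound 3 (0.01 log units; that floor lies within the scatter), so that change shows no gain in this assay. With thiophen-3-yl in place, neither methyl nor methylamino gives a readable number.

Going by these compounds, the true values of compound 2 and compound 3 remain open. So does whether a plain amino group or a chlorine atom at this position would give a readable number.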